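The source may report more compounds than this note shows. Statements on the series, on what has been measured and on what is new or still open speak of the compounds shown alone.

Three measured members share one core and differ only in the aryl group on the carbon with a double bond to nitrogen: compound 1 `COc1cc(COc2ccc(C(=O)N/N=C/c3cc(C(C)(C)C)c(O)c(C(C)(C)C)c3)cc2)cc(OC)c1OC`, compound 2 `COc1cc(/C=N/NC(=O)c2ccc(OCc3cc(OC)c(OC)c(OC)c3)cc2)cc(OC)c1O` and compound 3 `COc1cc(COc2ccc(C(=O)N/N=C/c3ccc(OC)c(OC)c3OC)cc2)cc(OC)c1OC`. In a physicochemical assay, with a stated time of 30 min (a higher number here means a weaker inhibitor, a lower number a stronger inhibitor), compound 2 gives 75 ug/mL, the highest of the two numbers in hand. In this assay compound 1 gives 62 ug/mL, which lies within the scatter of compound 2. In this assay compound 3 reports only a limit, > 100 ug/mL. That limit, (the limit of > 100 ug/mL in this assay, at which 1 of the 3 values shown sits), is all that sets the step of an at least 1.3-fold higher number from compound 2 to compound 3 (0.12 log units; that floor lies within the scatter), whose floor stays within the scatter.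

Compound 4 `COc1cc(COc2ccc(C(=O)N/N=C/c3cccc(O)c3)cc2)cc(OC)c1OC` is not yet measured in this assay. It differs from compound 2 by 3-hydroxyphenyl in place of 4-hydroxy-3,5-dimethoxyphenyl on a carbon with a double bond to nitrogen. For the measured compounds named here, the only measured step at this position, an at least 1.3-fold higher number from compound 2 to compound 3 (0.12 log units; that floor lies within the scatter), removes the same group and yields no more than a floor; no measured step removes the methoxy groups while keeping a hydroxyl. Given an at least 1.3-fold higher number from compound 2 to compound 3 (0.12 log units; that floor lies within the scatter), compound 4 is expected to sit close to compound 2, with the step of a 1.1-fold higher number from compound 2 to compound 4 (0.05 log units; within the scatter) not expected to resolve beyond the scatter. The estimate for compound 4 in this assay is 85 ug/mL, within 45 ug/mL to 160 ug/mL.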

Compound 4, half-maximal inhibitory concentration: > 100 ug/mL
Compound 4: no number, only a limit; the forecaster's own chance of this, stated with the estimate: 35%; middle value at least 1.1-fold (0.07 log units) from the limit.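

In this assay compound 4 reports only a limit, and it stands at the same limit as another member of the series: the limit of > 100 ug/mL in this assay, at which 2 of the 4 values shown sit.

The change to 3-hydroxyphenyl gives an at least 1.3-fold higher number from compound 2 to compound 4 (0.12 log units; that floor lies within the scatter) and that floor does not separate the two compounds. New here is that a hydroxyl kept on the aryl group, without the methoxy groups of compound 2, still ends at a limit and not at a readable number, while the step between compound 3 and compound 4 cannot be read.

From the compounds shown here alone, how far compound 3 and compound 4 lie past the limit stays open, and no order among the aryl groups at this position can be drawn from the values shown. Also open, going by these compounds, is whether an amine or a carboxylic acid in place of the hydroxyl on this aryl group would return a readable number.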